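The compounds below may be only part of what the source reports. "The series", "measured", "known", "first", "only" and "open" are said of these compounds alone.

Compounds measured so far in a functional assay for inhibition, with Homo sapiens as the target; a higher number here means a weaker inhibitor, a lower number a stronger inhibitor
- compound 1 `O=C(O)CCNC(=O)c1ccc2c(c1)C(=O)N(CCC1CCNCC1)C2` gives 27 nM
- compound 2 `CCCCS(=O)(=O)N[C@@H](CNC(=O)c1ccc2c(c1)C(=O)N(CCC1CCNCC1)C2)C(=O)O` gives 14 nM; 9 nM (2 entries)
- compound 3 `O=C(NCc1ccccc1)N[C@@H](CNC(=O)c1ccc2c(c1)C(=O)N(CCC1CCNCC1)C2)C(=O)O` gives 10 nM

Lower numbers mean stronger inhibition here, and compound 3 stands clearly under compound 1, by a modest margin (a 2.7-fold lower number from compound 1 to compound 3 (0.43 log units; beyond the scatter)). Going by the values given here, compound 2 has repeated entries (the several entries of compound 2 in this assay, 14 nM; 9 nM (2 entries)), and these lie close to the single number of compound 3 (10 nM), so the two cannot be put in a clear order.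

The next compound to be tested is compound 4 `O=C(NC[C@H](NS(=O)(=O)c1ccccc1)C(=O)O)c1ccc2c(c1)C(=O)N(CCC1CCNCC1)C2`, which carries phenylsulfonyl in place of benzylcarbamoyl on an amine nitrogen.

Among the compounds with values here, no measured step makes this exact swap. The closest guide is the step that adds the whole (benzylcarbamoyl)amino group to the chain, and even that change is only modest (a 2.7-fold lower number from compound 1 to compound 3 (0.43 log units; beyond the scatter)). The close numbers of compound 2 and compound 3 point the same way. A swap of one group for another at this place is therefore expected to change little in this assay, with no step beyond the scatter and no favoured direction. The expected step is small (no change at the digits printed from compound 3 to compound 4 (within the scatter)). For compound 4 the estimated value is 10 nM, with an expected range from 4 nM to 25 nM.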

Compound 4, half-maximal inhibitory concentration: 8 nM
Compound 4: middle estimate off by 1.3-fold (0.10 log units), on the high side, within the range that was stated.
By their numbers in this assay, from the lowest: compounds 4 and 3 (each within the scatter of the next); then compound 1.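

In this assay, phenylsulfonyl in place of benzylcarbamoyl on the amine nitrogen gives a 1.3-fold lower number from compound 3 to compound 4 (0.10 log units; within the scatter), so no difference between these two groups can be claimed, although benzylcarbamoyl carries a hydrogen-bond donor and phenylsulfonyl carries none. Adding the (phenylsulfonyl)amino group to the chain of compound 1 gives a 3.4-fold lower number from compound 1 to compound 4 (0.53 log units; beyond the scatter), a modest step of similar size to a 2.7-fold lower number from compound 1 to compound 3 (0.43 log units; beyond the scatter), so at this position the sulfonyl link can stand in for the carbamoyl link without losing that improvement. Compound 2, which has a butyl chain on the sulfonyl instead of a phenyl ring, gives numbers in the same region, and its repeated measurements show how much one compound can vary: the several entries of compound 2 in this assay, 14 nM; 9 nM (2 entries)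

The compounds shown leave open how much these numbers depend on the carboxylic acid, which all four carry, and whether a methyl group on the sulfonyl would stay in the same region as butyl and phenyl. Going by these compounds, it also remains open whether the opposite mirror-image arrangement at the chain carbon would behave alike.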